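Amide series: cyclopentylmethyl in place of the aryl carbonyl

The source may hold more compounds than are shown below. What is called first, only, known or untested is meant among the compounds shown, and "the series" means these compounds.

Three measured compounds share one core and differ only in the group on the carbonyl carbon of the amide. Compound 1 `Cc1ccc(C(=O)Nc2cc(-c3ccccc3)nn2-c2ccccc2)cc1` gives 64 nM in a functional assay on cells for positive allosteric modulation of metabotropic glutamate receptor 5 (Rattus norvegicus), read by calcium flux; on this read-out lower numbers stand for an effect already at smaller amounts and higher numbers for an effect only at larger amounts of compound. Compound 2 `O=C(Nc1cc(-c2ccccc2)nn1-c1ccccc1)c1cc([N+](=O)[O-])cc([N+](=O)[O-])c1` gives 65 nM in this assay, and compound 3 `O=C(Nc1cc(-c2ccccc2)nn1-c1ccccc1F)c1ccccc1` gives 104 nM in this assay. Compound 1 sits at one end of these three numbers, but both compound 2 and compound 3 lie within the scatter of it, so the three read as one level and no ordering among them is supported.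

Compound 4 `O=C(CC1CCCC1)Nc1cc(-c2ccccc2)nn1-c1ccccc1` is not yet measured. It differs from compound 1 in a single place: cyclopentylmethyl in place of 4-methylphenyl on a carbonyl carbon. The three measured compounds all carry a six-membered aromatic ring on the carbonyl carbon, so nothing measured here tells how a five-membered non-aromatic ring of carbon only behaves at that position. The step from compound 1 to compound 4 is therefore expected to be a loss, of moderate size, rather than none beyond the scatter, with wide uncertainty.

For compound 4 the estimate is 220 nM in this assay, within 70 nM to 800 nM, meaning an expected step of a 3.4-fold higher number from compound 1 to compound 4 (0.54 log units; beyond the scatter).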

Compound 4, half-maximal effective concentration: 350 nM
Compound 4: middle estimate off by 1.6-fold (0.20 log units), on the low side, within the range that was stated.
By their numbers in this assay, from the lowest: compounds 1, 2 and 3 (each within the scatter of the next); then compound 4.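

The group on the carbonyl carbon is not freely exchangeable: in this assay, cyclopentylmethyl in place of 4-methylphenyl gives a 5.5-fold higher number from compound 1 to compound 4 (0.74 log units; beyond the scatter), the only step shown for this position that lies beyond the scatter. Among the six-membered aromatic rings at this place, compound 1 gives 64 nM and compound 2 gives 65 nM, values within the scatter of each other, so a large change of substituents on that ring leaves the level in place, while this exchange of the whole group does not. Nothing available accounts for the step, and no explanation for it can be offered from these data.

This single change replaces the six-membered aromatic ring with a five-membered non-aromatic ring and also alters how the ring is attached to the carbonyl carbon, so the compounds shown do not separate these contributions. Cyclopentyl directly on the carbonyl carbon, phenylmethyl and cyclohexyl would each help to separate them, and the response of this position to a group carrying an amine or a carboxylic acid also remains open.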